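Replacing 2-chlorophenyl with 3-methylphenyl on the shared core

The source may report more compounds than this note shows. Statements on the series, on what has been measured and on what is new or still open speak of the compounds shown alone.

Values in an ADME assay on CHO cells (Cricetulus griseus) for cytotoxicity, read by LDH release; a higher number here means a weaker inhibitor, a lower number a stronger inhibitor:
- Compound 1 `CC(Oc1ccc(Cl)cc1Cl)C(=O)NCc1ccccc1`: 95000 nM
- Compound 2 `CC(Oc1ccc(Cl)cc1Cl)C(=O)NCc1ccc(Cl)cc1`: 39000 nM
- Compound 3 `CC(Oc1ccc(Cl)cc1Cl)C(=O)NCc1ccccc1Cl`: > 100000 nM (a limit of the assay)

Compound 3 stands at the limit of > 100000 nM in this assay, at which 1 of the 3 values shown sits. Going by these compounds, that reading is a limit and not a number, so the true position of compound 3 remains open.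

The next compound, compound 4 `Cc1cccc(CNC(=O)C(C)Oc2ccc(Cl)cc2Cl)c1`, carries 3-methylphenyl in place of 2-chlorophenyl on a saturated chain carbon bound to an amide-type nitrogen. This removes the chloro and brings in a methyl, a change not yet measured in this series.

Three measured steps offer guidance. One swap of hydrogen for chloro gave a 2.4-fold lower number from compound 1 to compound 2 (0.39 log units; beyond the scatter), while another gave an at least 1.0-fold higher number from compound 1 to compound 3 (0.02 log units; that floor lies within the scatter). Exchanging 4-chlorophenyl for 2-chlorophenyl gave an at least 2.5-fold higher number from compound 2 to compound 3 (0.40 log units; beyond the scatter). These steps are all small, and they do not all point the same way.

Compound 4 has no chloro on that ring, and compound 1, which also lacks one, gives 95000 nM. A small move towards a lower number is therefore expected in this assay, though the reading could again end at the limit. The expected change is an at least 1.3-fold lower number from compound 3 to compound 4 (0.12 log units; that floor lies within the scatter). For compound 4 the estimated value is 75000 nM, with an expected range from 35000 nM to 140000 nM.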

Compound 4, half-maximal inhibitory concentration: 45000 nM
The estimate for compound 4 lay 1.7-fold (0.22 log units) above the measured number, within the range that was stated.
By their numbers in this assay, from the lowest: compounds 2 and 4 (each within the scatter of the next); then compound 1. At a limit, above all of these: compound 3.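

In this assay, bringing in a methyl where a hydrogen stood gives a 2.1-fold lower number from compound 1 to compound 4 (0.32 log units; beyond the scatter), the first measured effect of a methyl on this ring, while 3-methylphenyl in place of 4-chlorophenyl gives a 1.2-fold higher number from compound 2 to compound 4 (0.06 log units; within the scatter), so these two rings cannot be told apart here. Set against 2-chlorophenyl, the same group gives an at least 2.2-fold lower number from compound 3 to compound 4 (0.34 log units; beyond the scatter), which sets a floor on the step rather than its full size, and it shows that a ring substituent at this place does not always leave the number high, with compound 3 remaining the one that goes against the lower readings of compound 2 and compound 4. The reading for compound 3 is a limit of the assay and not a number: the limit of > 100000 nM in this assay, at which 1 of the 4 values shown sits.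

The compounds shown leave open whether the kind of group or its place on the ring decides the reading, as methyl and chloro appear here only at different places on it. Also open, going by these compounds, is how a group of another kind, such as an amine or a carboxylic acid, would read on this ring.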